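Cytotoxicity in the cyclopropane-bridged purine series; compound 4 pending

The source may report more compounds than this note shows. Statements on the series, on what has been measured and on what is new or still open speak of the compounds shown alone.

Measured so far:
Compound 1 `CNc1nc(N)nc2c1ncn2/C=C1/CC1(CO)CO` gives 67000 nM in an ADME assay on BCBL1 cells (Homo sapiens) for cytotoxicity, with a stated time of 7 days; a higher number here means that more compound is tolerated, a lower number that less compound is tolerated.
Compound 2 `Nc1nc(OCC(F)(F)F)c2ncn(/C=C3/CC3(CO)CO)c2n1` gives only a limit of this assay, > 20000 nM.
Compound 3 `Nc1nc(NC2CC2)c2ncn(/C=C3/CC3(CO)CO)c2n1` gives 71500 nM.

Compound 3 holds the higher of the two numbers; its nearest neighbour is compound 1, and the step of a 1.1-fold higher number from compound 1 to compound 3 (0.03 log units; within the scatter) stays within the scatter. Compound 2 contributes no number, only (the limit of > 20000 nM in this assay, at which 1 of the 3 values shown sits).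

Compound 4 `CCCCCOc1nc(N)nc2c1ncn2/C=C1/CC1(CO)CO` differs from compound 3 by pentyloxy in place of cyclopropylamino on an aromatic carbon. The steps at the same aromatic carbon, a step that the limit leaves unreadable from compound 1 to compound 2 and a step that the limit leaves unreadable from compound 2 to compound 3, give no readable size. Nothing measured therefore points to a step beyond the scatter, and the expectation for a 1.2-fold lower number from compound 3 to compound 4 (0.08 log units; within the scatter) is no change beyond it. Compound 4 is estimated at 60000 nM, between 25000 nM and 130000 nM.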

Compound 4, half-maximal cytotoxic concentration: > 20000 nM
Compound 4 gave a limit, no number (the forecaster's own chance of this, stated with the estimate: 25%); the middle value does not contradict the limit.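

For the compounds shown here, compound 4, like compound 2, gives only a limit, so no step from compound 1, compound 2 or compound 3 to compound 4 can be read: the limit of > 20000 nM in this assay, at which 2 of the 4 values shown sit.
On these data alone, whether pentyloxy in place of cyclopropylamino moves the number in this assay beyond the scatter stays open.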